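This account rests on a few compounds, and the source may have more. Where it says the series, first, only, none or still open, it means among the compounds named here.

- Compound 1 `CCC(=O)Oc1c(C(C)C)cc2c3c1OC(=O)[C@@]31CCCC(C)(C)[C@@H]1CC2`: 113000 nM
- Compound 2 `CCCCCCCCCCCCCCCC(=O)Oc1c(C(C)C)cc2c3c1OC(=O)[C@@]31CCCC(C)(C)[C@@H]1CC2`: > 1000000 nM
- Compound 3 `CCCCCCCC/C=C/CCCCCCCC(=O)Oc1c(C(C)C)cc2c3c1OC(=O)[C@@]31CCCC(C)(C)[C@@H]1CC2`: 822000 nM

In an ADME assay on AGS cells (Homo sapiens) for cytotoxicity, read by neutral red uptake, with a stated time of 24 h (on this read-out lower numbers stand for stronger inhibition and higher numbers for weaker inhibition), compound 1 gives 113000 nM, the lower of the two actual numbers, while compound 3 gives 822000 nM. For compound 2 the value > 1000000 nM is a limit of the assay, not a number.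

Compound 4 `CC(C)c1cc2c3c(c1OC(=O)c1cccnc1)OC(=O)[C@@]31CCCC(C)(C)[C@@H]1CC2` has pyridin-3-yl in place of ethyl on a carbonyl carbon. Among the compounds with values here, the one measured step, an at least 1.2-fold lower number from compound 2 to compound 3 (0.08 log units; that floor lies within the scatter), involves no ring and offers little guidance here. The expectation therefore stays close to compound 1 at 113000 nM, with no step beyond the scatter, though the uncertainty is wide. The expected change is a 1.3-fold higher number from compound 1 to compound 4 (0.12 log units; within the scatter). Compound 4 is estimated at 150000 nM, with an expected range of 50000 nM to 500000 nM.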

Compound 4, half-maximal inhibitory concentration: 280000 nM
The estimate for compound 4 lay 1.9-fold (0.27 log units) below the measured number; low and high end bracket the measured number.
By their numbers in this assay, from the lowest: compound 1; then compound 4; then compound 3. At a limit, above all of these: compound 2.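

On the carbonyl carbon of this ester, pyridin-3-yl in place of ethyl gives a 2.5-fold higher number from compound 1 to compound 4 (0.39 log units; beyond the scatter) in this assay. Within the data shown here, this is the first step that clearly exceeds the scatter, and it shows that an aromatic ring can be placed here and that the swap shifts the number modestly. Nothing measured here gives a reason for this step. As far as these compounds go, it remains open whether phenyl, which has no ring nitrogen, would read closer to compound 1 or compound 4. From the compounds shown here alone, the result for pyridin-4-yl, with its ring nitrogen placed differently, also remains open.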